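The compounds below may be only part of what the source reports. "The series", "measured", "known", "first", "only" and "open" are said of these compounds alone.

In an assay on LtK cells with ATP-sensitive inward rectifier potassium channel 11 (Homo sapiens) as the target (a higher number here means that more compound is needed for the effect, a lower number that less compound is needed), compound 1 `CC(=O)Nc1c(C(O)(C(F)(F)F)C(F)(F)F)ccc2ccccc12` gives 18 nM. Compound 2 `CCC(C)C(=O)Nc1c(C(O)(C(F)(F)F)C(F)(F)F)ccc2ccccc12` gives 177000 nM, and compound 3 `O=C(Nc1c(C(O)(C(F)(F)F)C(F)(F)F)ccc2ccccc12)c1cccc(Cl)c1` gives 98 nM, the second highest of the three numbers, with compound 1 nearest at a 5.4-fold higher number from compound 1 to compound 3 (0.74 log units; beyond the scatter) and compound 2 furthest at a 1800-fold lower number from compound 2 to compound 3 (3.26 log units; beyond the scatter). Compound 4 `Cc1ccc(C(=O)Nc2c(C(O)(C(F)(F)F)C(F)(F)F)ccc3ccccc23)cc1` differs from compound 3 in one place: 4-methylphenyl in place of 3-chlorophenyl on a carbonyl carbon. The two measured steps exchange a methyl or a sec-butyl for another group on the carbonyl carbon; neither swaps one aromatic ring for another, so they bear on this step only loosely, though both show that the group on the carbonyl carbon can move the number strongly. With one six-membered aromatic ring leaving and one entering, the step of a 1.0-fold higher number from compound 3 to compound 4 (0.01 log units; within the scatter) is expected to be small or within the scatter. Compound 4 is therefore estimated at 100 nM, within 30 nM to 400 nM.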

Compound 4, half-maximal effective concentration: 76 nM
The estimate for compound 4 lay 1.3-fold (0.12 log units) above the measured number; the measured number falls inside the stated range.
By their numbers in this assay, from the lowest: compound 1; then compounds 4 and 3 (each within the scatter of the next); then compound 2.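

In this assay, among the compounds shown here, this is the first exchange of one aromatic ring for another on the carbonyl carbon, and a 1.3-fold lower number from compound 3 to compound 4 (0.11 log units; within the scatter) shows that 3-chlorophenyl and 4-methylphenyl cannot be told apart at this position. Both a 2300-fold lower number from compound 2 to compound 4 (3.37 log units; beyond the scatter) and a 4.2-fold higher number from compound 1 to compound 4 (0.63 log units; beyond the scatter) run the same way as the steps to compound 3, so a second aromatic ring also lies far below sec-butyl but beyond the scatter above methyl. No available evidence explains these differences. The compounds shown leave open whether a phenyl ring carrying an amine or a carboxylic acid would behave like these two rings. They also leave open whether a straight propyl chain would give a number as high as sec-butyl.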